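Cyclopropyloxy in place of cyclopropyl on the carbonyl carbon

This account rests on a few compounds, and the source may have more. Where it says the series, first, only, none or still open, it means among the compounds named here.

In an ADME assay on the whole organism (Rattus norvegicus, strain Wistar Han), at a dose of 0.5 mg/kg by the intravenous route (on this read-out higher numbers stand for a longer-lived compound and lower numbers for a shorter-lived compound), compound 2 (`O=C(C1CC1)N1CCc2nc(C3(C(=O)Nc4ccc(F)cc4)CCC3)ccc21`) gives 1.2 h as a measured value. For the measured compounds named here, the only other measured compound is compound 1 (`O=C(Nc1ccc(Cl)cc1)C1(c2ccc3c(n2)CCN3c2ccccn2)CCC1`) with 2.2 h on the same read-out. Going by the values given here, these two values lie within the scatter of each other, so compound 2 stands level with compound 1 on the numbers so far. Among the compounds with values here, no measured step between compounds that differ in one place is available to guide the next estimate.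

The change from compound 2 to compound 3 (`O=C(OC1CC1)N1CCc2nc(C3(C(=O)Nc4ccc(F)cc4)CCC3)ccc21`) is cyclopropyloxy in place of cyclopropyl on a carbonyl carbon and the rest of the structure stays the same. Within the data shown here, with no measured precedent for this change, the data set no direction, and no step beyond the scatter is expected in this assay for now. The estimate therefore starts from compound 2 at 1.2 h and keeps a wide range. The estimated step of a 1.1-fold higher number from compound 2 to compound 3 (0.03 log units; within the scatter) stays within the scatter. For compound 3 the expected value is 1.3 h and the estimated range runs from 0.6 h to 2.7 h on this read-out.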

Compound 3, mean residence time: 2.7 h
Compound 3: the middle estimate sits 2.1-fold (0.32 log units) below what was measured, and the stated range covers the measured number.
By their numbers in this assay, from the lowest: compounds 2, 1 and 3 (each within the scatter of the next, the first and the last beyond it).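

In this assay, for the compounds shown here, the carbonyl carbon on the amide-type ring nitrogen proves to be a place where the read-out responds: cyclopropyloxy in place of cyclopropyl gives a 2.3-fold higher number from compound 2 to compound 3 (0.35 log units; beyond the scatter) and provides the first step between compounds that differ in one place. The cyclopropyl ring is present on both sides of this step, and the counted difference is the added oxygen, which takes the group from cyclopropylcarbonyl to cyclopropyloxycarbonyl and brings one hydrogen-bond acceptor. Nothing in the data accounts for the step, which remains an observation on a single pair.

On these data alone, it remains open whether the same direction holds for other groups on this carbonyl carbon, such as a tert-butoxy group, or an amine such as dimethylamino. A single pair also leaves open whether the step carries over to a different anilide, such as the 4-chlorophenyl amide present in compound 1, or whether it depends on the rest of compound 3.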